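Trimming a chloro from a dichlorophenyl imine

The compounds below may be only part of what the source reports. "The series", "measured", "known", "first", "only" and "open" are said of these compounds alone.

Three compounds in this set share a fused core and have been measured in an ADME assay on cells (Rhabdomyosarcoma cell, Homo sapiens) for cytotoxicity, read by MTT assay, with a stated time of 72 h; a higher number here means that more compound is tolerated, a lower number that less compound is tolerated. Compound 1, `Nc1sc2c(c1-c1nc3cc(Cl)ccc3s1)CCCC2`, carries a free amine and gives 43.5 ug/mL. Compound 2, `Fc1ccccc1/C=N/c1sc2c(c1-c1nc3ccccc3s1)CCC2`, has an imine linked to a fluorophenyl ring on a smaller saturated ring, and gives 270 ug/mL. Compound 3, `Clc1ccc(/C=N/c2sc3c(c2-c2nc4ccccc4s2)CCCC3)c(Cl)c1`, has an imine linked to a dichlorophenyl ring and gives 56.6 ug/mL. On these numbers compound 3 stands second highest of the three: it sits within the scatter of compound 1, while compound 2 lies clearly higher, beyond the scatter.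

The next compound, compound 4, `Clc1ccccc1/C=N/c1sc2c(c1-c1nc3ccccc3s1)CCCC2`, is not yet measured. It differs from compound 3 in one place: hydrogen in place of chloro on an aromatic carbon. Among the measured compounds shown here, no measured pair in this set shows this exact change, so its effect must be guessed. The only other imine, compound 2, is tolerated more than compound 3, but it also differs in ring size and halogen, so it gives weak guidance. A modest rise in tolerated concentration is expected, with the step from a 1.6-fold higher number from compound 3 to compound 4 (0.20 log units; within the scatter) possibly still inside the scatter. For compound 4 the estimated value in this assay is 90 ug/mL, with a range from 40 ug/mL to 250 ug/mL.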

Compound 4, half-maximal cytotoxic concentration: 332 ug/mL
Beside the measured number, compound 4's estimate is 3.7-fold (0.57 log units) below it; measured number above the stated range.
By their numbers in this assay, from the lowest: compounds 1 and 3 (each within the scatter of the next); then compounds 2 and 4 (each within the scatter of the next).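

Among the compounds shown here, the change from 2,4-dichlorophenyl to 2-chlorophenyl is the first comparison in this set in which only one place differs, and in this assay it gives a 5.9-fold higher number from compound 3 to compound 4 (0.77 log units; beyond the scatter) as a step beyond the scatter. It shows that this one position, on an aromatic carbon para to a large group and meta to a chloro group, has a clear bearing on the number: with the rest of the structure the same, a single chlorine atom separates a compound that is tolerated at a lower concentration from one tolerated at a higher concentration. Nothing measured here speaks to why the number moves this far.

The compounds shown leave open whether hydrogen is special at this position, or whether another group in the same place, such as a fluoro, a methoxy or an amine, would give a similar number. Also open, going by these compounds, is how the number would respond if the remaining chloro gave way to hydrogen as well, leaving a plain phenyl ring on the imine of the same core.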